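The source may hold more compounds than are shown below. What is called first, only, known or untested is meant among the compounds shown, and "the series" means these compounds.

Compound 1 (`COc1ccccc1OCC1SCCN1C(=O)C[S+](C)[O-]`) 25 mg/kg
Compound 2 (`COc1ccccc1OCC1SCCN1C(=O)CC(C)=O`) 30 mg/kg
Compound 3 (`CCOC(=O)CCC(=O)N1CCSC1COc1ccccc1OC`) 24 mg/kg

All three values come from a functional assay on the whole organism for inhibition, with Cavia porcellus as the target (on this read-out lower numbers stand for an effect already at smaller amounts and higher numbers for an effect only at larger amounts of compound), and they lie close together. Compound 3 gives 24 mg/kg and stands level with the other two within the scatter (a 1.0-fold lower number from compound 1 to compound 3 (0.02 log units; within the scatter)) (a 1.3-fold lower number from compound 2 to compound 3 (0.10 log units; within the scatter)).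

Compound 4 (`CCOC(=O)C(C)(C)C(=O)N1CCSC1COc1ccccc1OC`) has not yet been measured. It keeps the core of compound 3 and differs in one place (1-(ethoxycarbonyl)-1-methylethyl in place of 2-(ethoxycarbonyl)ethyl on a carbonyl carbon): 1-(ethoxycarbonyl)-1-methylethyl in place of 2-(ethoxycarbonyl)ethyl on a carbonyl carbon.

Among the measured compounds shown here, three measured steps bear on this change, each an exchange on a saturated chain carbon bound to a carbonyl carbon. Besides the two already given there is a third (a 1.2-fold higher number from compound 1 to compound 2 (0.08 log units; within the scatter)). All three stay within the scatter, so the number has not so far answered to changes in this chain. None of them brings in the 1-(ethoxycarbonyl)-1-methylethyl group, and the data show nothing for it directly. In this assay no step beyond the scatter is therefore expected, and neither direction is favoured. The expected step is small (a 1.0-fold higher number from compound 3 to compound 4 (0.02 log units; within the scatter)). For compound 4 the estimated value is 25 mg/kg, with an expected range (11 mg/kg to 55 mg/kg).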

Compound 4, dose for half-maximal effect: 61 mg/kg
Compound 4: middle estimate off by 2.4-fold (0.39 log units), on the low side; the whole stated range lies below it.
By their numbers in this assay, from the lowest: compounds 3, 1 and 2 (each within the scatter of the next); then compound 4.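

In this assay, among the compounds shown here, the chain on the carbonyl carbon proves not to be indifferent after all: 1-(ethoxycarbonyl)-1-methylethyl in place of 2-(ethoxycarbonyl)ethyl gives the first step beyond the scatter in this set, though only a modest one (a 2.5-fold higher number from compound 3 to compound 4 (0.41 log units; beyond the scatter)). The higher number also holds with 1-(ethoxycarbonyl)-1-methylethyl in place of 2-oxopropyl (a 2.0-fold higher number from compound 2 to compound 4 (0.31 log units; beyond the scatter)) and in place of the smaller sulfur-bearing group (a 2.4-fold higher number from compound 1 to compound 4 (0.39 log units; beyond the scatter)), so that compound 4 stands apart from the other three, which remain within the scatter of one another. Nothing measured here accounts for this rise.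

Going by these compounds, it remains open whether a 1-(ethoxycarbonyl)ethyl group, with a single methyl, would already raise the number, or whether the step appears only with the 1-(ethoxycarbonyl)-1-methylethyl group. Also open, on these data alone, is whether the higher number would persist with a carboxylic acid in place of the ethyl ester, or with a 1-acetyl-1-methylethyl group, which would show whether the step depends on the ester at all.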